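Plasma stability of the shared core: chloro to methyl

A few compounds are considered here, and "the series" means these few. Any claim that something is new, unique, unknown or untested is made for them only; others in the source may bear on it.

Measured compounds:
- compound 1 `Cc1c(OCCCCOc2ccc(C(=O)O)cc2Cl)ccc(C(=O)CC2CCCC2)c1O`: 120%
- compound 2 `Cc1c(OCCCCOc2ccc(C(=O)O)cc2)ccc(C(=O)CC(C)C)c1O`: 95%
- compound 3 `Cc1c(OCCCCOc2ccc(C(=O)O)cc2F)ccc(C(=O)CC(C)C)c1O`: 106%

In an ADME assay on a cell-free system (plasma, Rattus norvegicus) for metabolic stability, read by LC-MS, with a stated time of 60 min, tested at 100 uM (on this read-out higher numbers stand for a more stable compound and lower numbers for a less stable compound), compound 1 gives the highest of the three numbers; compound 3 sits nearest, and compound 2 furthest, both beyond the scatter below compound 1. Compound 4 `Cc1cc(C(=O)O)ccc1OCCCCOc1ccc(C(=O)CC2CCCC2)c(O)c1C` has not been measured. It differs from compound 1 in one place: methyl in place of chloro on an aromatic carbon. The group sits on an aromatic carbon of a six-membered aromatic ring of carbon only, ortho to a large group and meta to a carboxy group.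

For the measured compounds named here, only one measured step touches that position: a number 11 percentage points higher from compound 2 to compound 3 (beyond the scatter), a fluoro entering where hydrogen stood. Going by the values given here, no measured step swaps chloro for methyl, and compound 1 and compound 3 differ in two places, so their gap cannot be read as a single change. Among the compounds with values here, the one step at this position was modest and upward; a methyl is not a halogen, so the expected step of a number 10 percentage points lower from compound 1 to compound 4 (within the scatter) is none beyond the scatter, with compound 4 expected to remain close to compound 1. The estimate for compound 4 is 110%, expected to fall between 90% and 130%.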

Compound 4, percent of the compound remaining: 99%
Compound 4: the middle estimate sits 11 percentage points above what was measured, and the stated range covers the measured number.
By their numbers in this assay, from the lowest: compounds 2, 4 and 3 (each within the scatter of the next, the first and the last beyond it); then compound 1.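

Methyl in place of chloro gives a number 21 percentage points lower from compound 1 to compound 4 (beyond the scatter) in this assay, the first direct reading at this position of one substituent exchanged for another. The only earlier step here, a number 11 percentage points higher from compound 2 to compound 3 (beyond the scatter), ran upward on a different ketone side chain, so the read-out at this position has now moved beyond the scatter in both directions across the two changes shown. Nothing measured bears on why methyl and chloro differ here.

Open, from the compounds shown here alone, is what a methoxy group, a bromo group or a trifluoromethyl group would give at this position, and whether methyl in place of chloro gives a similar step with the ketone side chain of compound 2. Also open, going by these compounds, is how hydrogen at this position would read on the core of compound 1, which would set chloro and methyl against a common reference.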